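The compounds below may be only part of what the source reports. "The series", "measured", "known", "first", "only" and "open" are said of these compounds alone.

Compound 1 `CCOC(=O)/C=C1/C(=O)Nc2ccccc21` and compound 2 `CC(C)(C)OC(=O)/C=C1/C(=O)Nc2ccccc21` share one core and differ only in the ester group. In a toxicity assay on L02 cells (Homo sapiens) for cytotoxicity, read by CCK-8 assay, with a stated time of 72 h (a lower number here means a stronger inhibitor, a higher number a weaker inhibitor), compound 1 gives 4230 nM, while compound 2 gives 2450 nM. Among the compounds with values here, the single comparison available, a 1.7-fold lower number from compound 1 to compound 2 (0.24 log units; within the scatter), does not reach beyond the scatter. Among these two numbers compound 2 stands at one end and compound 1 at the other, with a gap that stays within the scatter, so neither can be called the stronger.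

Compound 3 `CC(C)(C)OC(=O)/C=C1/C(=O)N(Cc2ccccc2)c2ccccc21` differs from compound 2 by benzyl in place of hydrogen on an amide-type nitrogen in a ring. Within the data shown here, no measured step touches this nitrogen; the only step known, a 1.7-fold lower number from compound 1 to compound 2 (0.24 log units; within the scatter), concerns the ester oxygen and stayed within the scatter, so it bears on compound 3 only by showing how little the numbers have moved so far. Nothing therefore supports a step beyond the scatter in either direction, though the change itself is larger than the one already seen, and the range is accordingly set wide. Compound 3 is expected to give about 2200 nM, within a range of 600 nM to 8000 nM. The expected step is a 1.1-fold lower number from compound 2 to compound 3 (0.05 log units; within the scatter).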

Compound 3, half-maximal inhibitory concentration: 5030 nM
For compound 3 the middle estimate is 2.3-fold (0.36 log units) below the measured one, within the range that was stated.
By their numbers in this assay, from the lowest: compounds 2, 1 and 3 (each within the scatter of the next, the first and the last beyond it).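

In this assay the amide-type nitrogen in the ring now has a measured step of its own: benzyl in place of hydrogen produces a 2.1-fold higher number from compound 2 to compound 3 (0.31 log units; beyond the scatter) and is the first step among these compounds to lie beyond the scatter, though only modestly. The earlier pair differed only in the ester group, so it said nothing about this nitrogen, whereas this step shows that the amide hydrogen can be replaced by benzyl and that, in this one case, the change moves the number towards a weaker inhibitor. The compounds shown offer no measured evidence that bears on what lies behind this shift.

A single substituent on this nitrogen cannot show whether the shift is particular to benzyl or would also appear with a methyl, a longer alkyl chain or a chain ending in an amine. Going by these compounds, it also remains open whether a fluorine or a methoxy group on the benzyl ring would move the number further, and whether the same nitrogen change would produce a similar step with the ethyl ester of compound 1 or with a carboxylic acid in place of the ester.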